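Trifluoromethyl to methoxy on compound 2

This account rests on a few compounds, and the source may have more. Where it says the series, first, only, none or still open, it means among the compounds named here.

compound 1 `O=S(=O)(Nc1ccc(-c2nc3ccccc3o2)cc1)c1cccc(Cl)c1`: > 100000 nM (a limit, not a number)
compound 2 `O=S(=O)(Nc1ccc(-c2nc3ccccc3o2)cc1)c1ccc(C(F)(F)F)cc1`: 94000 nM

Among the measured compounds shown here, in an ADME assay on HEK293 cells (Homo sapiens) for cytotoxicity, read by resazurin assay, with a stated time of 48 h (a higher number here means that more compound is tolerated, a lower number that less compound is tolerated), compound 2 gives the only actual number of the pair (94000 nM). Compound 1 stands at a limit of the assay (> 100000 nM). Compound 3 `COc1ccc(S(=O)(=O)Nc2ccc(-c3nc4ccccc4o3)cc2)cc1` carries methoxy in place of trifluoromethyl on an aromatic carbon para to a large group. For the measured compounds named here, no measured step is available, so the expectation rests on compound 2 (94000 nM) alone, and no shift beyond the usual scatter is expected. The expected change is a 1.1-fold lower number from compound 2 to compound 3 (0.04 log units; within the scatter) and remains within that scatter. Compound 3 is estimated at 85000 nM (expected range 35000 nM to 150000 nM).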

Compound 3, half-maximal cytotoxic concentration: > 100000 nM
Compound 3 ended at the assay's limit (the forecaster's own chance of this, stated with the estimate: 45%); at least 1.1-fold (0.07 log units) between middle value and limit.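

In this assay, among the compounds shown here, methoxy in place of trifluoromethyl on this aromatic carbon gives an at least 1.0-fold higher number from compound 2 to compound 3 (0.02 log units; that floor lies within the scatter), so the one readable step at this position shows no change beyond the scatter. Compound 3 stands at a limit, not a number, so how far the step reaches stays hidden: the limit of > 100000 nM in this assay, at which 2 of the 3 values shown sit. The step between compound 1 and compound 3 cannot be read.

On these data alone, whether an amine or a carboxylic acid on this aromatic carbon would give a number clearly lower than that of compound 2 remains open. So does the true size of the step to compound 3.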